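From benzyl to propyl in a cell assay

A few compounds are considered here, and "the series" means these few. Any claim that something is new, unique, unknown or untested is made for them only; others in the source may bear on it.

In a functional assay on WM-115 cells (Homo sapiens) for inhibition, read by fluorescence and SYBR Green assay (on this read-out higher numbers stand for an effect only at larger amounts of compound and lower numbers for an effect already at smaller amounts), compound 1 `N=C(NCCCCCCCN)c1ccc(OCCCCCCCCOc2ccc(C(=N)NCCCCCCCN)cc2)cc1` gives 46300 nM, and compound 2 `N=C(N)c1ccc(OCCCN(CCCOc2ccc(C(=N)N)cc2)Cc2ccccc2)cc1` gives 51800 nM. Going by the values given here, these are the only two measurements so far, and compound 2 stands within the usual scatter of compound 1. Compound 3 `CCCN(CCCOc1ccc(C(=N)N)cc1)CCCOc1ccc(C(=N)N)cc1` has not yet been measured in this assay. It carries ethyl in place of phenyl on a saturated chain carbon bound to an amine nitrogen, which also reads as benzyl to propyl. Among the compounds with values here, no measured pair isolates a change of this kind, so the data offer no direct guide. Compound 1 at 46300 nM and compound 2 at 51800 nM are clearly different structures with values that still fall within the scatter, so no shift beyond the scatter is expected. The expected step is small, a 1.2-fold lower number from compound 2 to compound 3 (0.06 log units; within the scatter). For compound 3 the estimate is 45000 nM, with an expected range from 18000 nM to 110000 nM.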

Compound 3, half-maximal effective concentration: 864000 nM
Compound 3: the middle estimate sits 19-fold (1.28 log units) below what was measured; measured number above the stated range.
By their numbers in this assay, from the lowest: compounds 1 and 2 (each within the scatter of the next); then compound 3.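

In this assay, ethyl in place of phenyl on a saturated chain carbon bound to an amine nitrogen gives a 17-fold higher number from compound 2 to compound 3 (1.22 log units; beyond the scatter), so this place in the structure is far from indifferent to what it carries. Going by these compounds alone, the near-equal numbers of the two earlier compounds could not show this, as they differ in more than one place; this single change, with the six-membered aromatic ring and 6 heavy atoms leaving and 2 heavy atoms entering, is the first step to go beyond the scatter. Nothing at hand explains why the step is so large.

The compounds shown do not separate the loss of the aromatic ring from the loss of carbon atoms. A cyclohexylmethyl group or a longer chain such as hexyl at this place would bear on that question, and a pyridylmethyl group would test how far the ring itself can vary.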